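Methyl for fluoro on the benzyl group of compound 3

The compounds below may be only part of what the source reports. "The series", "measured", "known", "first", "only" and "open" are said of these compounds alone.

Compound 3 `O=C1/C(=N\NC(=S)Nc2ccc(Cl)cc2)c2cc(Br)ccc2N1Cc1ccc(F)cc1` gives 196000 nM in a functional assay on L1210 cells (Mus musculus), with a stated time of 48 h (on this read-out higher numbers stand for weaker inhibition and lower numbers for stronger inhibition), the highest of the three numbers: compound 1 `O=C1Nc2ccc(Br)cc2/C1=N/NC(=S)Nc1ccc(Cl)cc1` gives 88000 nM, and compound 2 `Cc1ccc(CN2C(=O)/C(=N\NC(=S)Nc3ccc(Cl)cc3)c3cc(Cl)ccc32)cc1` gives 9800 nM. Going by the values given here, the one measured step bearing on this series is a 2.2-fold higher number from compound 1 to compound 3 (0.35 log units; beyond the scatter). Compound 4 `Cc1ccc(CN2C(=O)/C(=N\NC(=S)Nc3ccc(Cl)cc3)c3cc(Br)ccc32)cc1` differs from compound 3 by methyl in place of fluoro on an aromatic carbon. Among the compounds with values here, no measured step matches this change directly; compound 2 carries the same 4-methylbenzyl group on a core with chloro in place of bromo, and its number stands well below that of compound 3. A lower number is therefore expected for compound 4, with the step of a 4.9-fold lower number from compound 3 to compound 4 (0.69 log units; beyond the scatter) estimated to lie between the two measured values. The estimate for compound 4 in this assay is 40000 nM, within 12000 nM to 150000 nM.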

Compound 4, half-maximal inhibitory concentration: 193000 nM
Beside the measured number, compound 4's estimate is 4.8-fold (0.68 log units) below it; the whole stated range lies below it.
By their numbers in this assay, from the lowest: compound 2; then compound 1; then compounds 4 and 3 (each within the scatter of the next).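

Fluoro and methyl on this aromatic carbon cannot be told apart in this assay, with a 1.0-fold lower number from compound 3 to compound 4 (0.01 log units; within the scatter), and 4-methylbenzyl in place of the amide hydrogen gives a 2.2-fold higher number from compound 1 to compound 4 (0.34 log units; beyond the scatter), much like the step seen with 4-fluorobenzyl. With 4-methylbenzyl held constant, bromo in place of chloro on the core gives a 20-fold higher number from compound 2 to compound 4 (1.29 log units; beyond the scatter), which isolates the halogen as the large change among these compounds. No evidence is available to explain these steps. From the compounds shown here alone, it remains open whether chloro gives a similar gain with 4-fluorobenzyl, and whether an amine or a carboxylic acid on the benzyl ring would shift the number.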